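This account rests on a few compounds, and the source may have more. Where it says the series, first, only, none or still open, it means among the compounds named here.

Measured compounds in a functional assay on A549 cells (Homo sapiens) for cytotoxicity, read by MTT assay, with a stated time of 72 h; on this read-out higher numbers stand for weaker inhibition and lower numbers for stronger inhibition:
- compound 1, `COc1ccc(-c2ccnc(C(=O)Nc3ccc(Oc4ccnc5[nH]ccc45)cc3)n2)cc1`, 13300 nM
- compound 2, `O=C(Nc1ccc(Oc2ccnc3[nH]ccc23)cc1)c1cc(-c2ccccc2)ncn1`, 140 nM
- compound 3, `O=C(Nc1ccc(Oc2ccnc3[nH]ccc23)c(F)c1)c1cc(-c2ccccc2)ncn1`, 180 nM

Compound 3 gives the second highest of the three numbers in this assay . Its nearest neighbour is compound 2, from which it differs only by a fluoro in place of hydrogen, and that step, a 1.3-fold higher number from compound 2 to compound 3 (0.11 log units; within the scatter), lies within the scatter. The furthest number is that of compound 1, which differs from the others both in the arrangement of the shared core and by a methoxy group on the phenyl, so no single step can be read from it.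

Compound 4, `O=C(Nc1ccc(Oc2ccnc3[nH]ccc23)c(F)c1)c1cc(-c2ccc(C(F)(F)F)cc2)ncn1`, differs from compound 3 by trifluoromethyl in place of hydrogen on an aromatic carbon, a change that reads as phenyl to 4-(trifluoromethyl)phenyl and sits para to a large group. For the measured compounds named here, no measured step bears on this change; the only phenyl-substituted compound, compound 1, carries a second difference as well. In this assay compound 4 is therefore expected near compound 3, with a 1.4-fold higher number from compound 3 to compound 4 (0.14 log units; within the scatter) treated as uncertain and given a wide range. The estimate for compound 4 is 250 nM, between 70 nM and 1500 nM.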

Compound 4, half-maximal inhibitory concentration: 2220 nM
Estimate against measurement, compound 4: 8.9-fold (0.95 log units) below; the whole stated range lies below it.
By their numbers in this assay, from the lowest: compounds 2 and 3 (each within the scatter of the next); then compound 4; then compound 1.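

In this assay, for the compounds shown here, trifluoromethyl in place of hydrogen on the aromatic carbon para to a large group gives a 12-fold higher number from compound 3 to compound 4 (1.09 log units; beyond the scatter), the first single-place change that lies beyond the scatter. The phenyl of compound 3 is therefore not indifferent to substitution at this position, unlike the fluoro change in another place, a 1.3-fold higher number from compound 2 to compound 3 (0.11 log units; within the scatter), which lies within the scatter. Nothing at hand accounts for the size of the trifluoromethyl step.

As far as these compounds go, whether the higher number belongs to trifluoromethyl alone or to any substituent at this position stays open, and a chloro, hydroxyl or amine on the same carbon would separate the two. Methoxy on the phenyl appears only in compound 1, whose core arrangement also differs, so it gives no clean reading of this position.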